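Bromo for isobutoxy on the outer ring: expected cytotoxicity

This account rests on a few compounds, and the source may have more. Where it says the series, first, only, none or still open, it means among the compounds named here.

In an ADME assay on HEK293 cells (Homo sapiens) for cytotoxicity, read by CellTiter-Glo and resazurin assay, with a stated time of 72 h (on this read-out lower numbers stand for an effect already at smaller amounts and higher numbers for an effect only at larger amounts of compound), compound 3 `CCOC(=O)CCCCCOc1cccc(CN(C(=O)c2ccc(-c3cccc(OCC(C)C)c3)cc2)C(C)C)c1` gives only a limit, > 26000 nM. Compound 1 `CC(C)COc1cccc(-c2ccc(C(=O)N(Cc3cccc(OCCCCCC(=O)O)c3)C(C)C)cc2)c1` likewise gives a limit, > 26000 nM. Compound 2 `CCOc1cccc(-c2ccc(C(=O)N(Cc3cccc(OCCCCCC(=O)O)c3)C(C)C)cc2)c1` also gives a limit, > 20800 nM. The step that the two limits leave unreadable from compound 1 to compound 2 and the step that the two limits leave unreadable from compound 1 to compound 3 therefore carry no size, since the limit of > 26000 nM in this assay, at which 2 of the 3 values shown sit, and the limit of > 20800 nM in this assay, at which 1 of the 3 values shown sits, bound all three values. Compound 3 thus stands at the limit together with the other two compounds. Compound 4 `CCOC(=O)CCCCCOc1cccc(CN(C(=O)c2ccc(-c3cccc(Br)c3)cc2)C(C)C)c1` differs from compound 3 by bromo in place of isobutoxy on an aromatic carbon. For the measured compounds named here, no measured step touches a substituent of this kind on that ring, and the two measured steps give no size to lean on. For compound 4 the expected step is a number no higher from compound 3 to compound 4 (the limit leaves the size open), within the scatter, most likely again reported as a limit. For compound 4 the estimated value in this assay is 26000 nM, from 10000 nM to 60000 nM.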

Compound 4, half-maximal effective concentration: > 26000 nM
Compound 4: no number, only a limit; the forecaster's own chance of this, stated with the estimate: 80%; the middle value sits exactly at the limit.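

In this assay compound 4 gives > 26000 nM, which is a limit. For the compounds shown here, compound 3 is also recorded only as a limit, so no step from compound 3 to compound 4 can be read. The compounds shown leave open the concentration at which any of them becomes cytotoxic, and whether bromo and isobutoxy differ at all.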